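A methyl-oxazole in place of the pyrazole on the shared core

The source may report more compounds than this note shows. Statements on the series, on what has been measured and on what is new or still open speak of the compounds shown alone.

Measured compounds:
- compound 1, `CS(=O)(=O)Nc1cccc2c1CCC2c1ncc[nH]1`, > 10000 nM
- compound 2, `c1cc(-c2cn[nH]c2)c2c(c1)C(c1ncc[nH]1)CC2`, 319 nM
- compound 3, `Clc1ccc2c(c1-c1ccn[nH]1)CCC2c1ncc[nH]1`, > 10000 nM

Within the data shown here, in a functional assay on CHO cells for agonist activity at Alpha-1D adrenergic receptor (Homo sapiens), read by FLIPR and calcium flux (a lower number here means that less compound is needed, a higher number that more compound is needed for the effect), compound 2 gives 319 nM, the only number in the set. Compound 1 reaches only a limit of > 10000 nM in this assay. Compound 3 likewise reaches only a limit of > 10000 nM. Among the measured compounds shown here, the one step between two compounds that differ in a single place, an at least 31-fold lower number from compound 1 to compound 2 (1.49 log units; beyond the scatter), shows how much the group on that aromatic carbon matters; the limit of > 10000 nM in this assay, at which 2 of the 3 values shown sit, marks where the weaker compounds sit.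

Compound 4, `Cc1oncc1-c1cccc2c1CCC2c1ncc[nH]1`, is not yet measured. Its change from compound 2 is 5-methyl-1,2-oxazol-4-yl in place of 1H-pyrazol-4-yl on an aromatic carbon. For the measured compounds named here, no measured step covers this exact swap, so the expectation rests on compound 2 alone and on the large gain seen with the pyrazol-4-yl group. Compound 4 is expected to be weaker than compound 2, with an estimated step of a 9.4-fold higher number from compound 2 to compound 4 (0.97 log units; beyond the scatter). The estimate for compound 4 is 3000 nM, expected to lie between 700 nM and 15000 nM.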

Compound 4, half-maximal effective concentration: > 10000 nM
Compound 4 was reported as a limit; the forecaster's own chance of this, stated with the estimate: 35%; middle value at least 3.3-fold (0.52 log units) from the limit.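

At this aromatic carbon, putting 5-methyl-1,2-oxazol-4-yl in place of 1H-pyrazol-4-yl gives an at least 31-fold higher number from compound 2 to compound 4 (1.49 log units; beyond the scatter) in this assay. A five-membered aromatic ring with 2 hetero atoms is therefore not enough on its own to keep the effect: the two groups share that ring, but the entering group has 6 heavy atoms and 0 hydrogen-bond donors, against 5 and 1 for the group that leaves. Compound 1 and compound 4 both sit at a limit, so the step between them cannot be read, and compound 2 remains the only compound with a number: the limit of > 10000 nM in this assay, at which 3 of the 4 values shown sit.

From the compounds shown here alone, it remains open whether the loss follows the added methyl or the change of ring atoms, which an unsubstituted 1,2-oxazol-4-yl or a methyl-bearing pyrazol-4-yl could separate. Also open, going by these compounds, is how a primary amine or a carboxylic acid on this carbon would read in this assay.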